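Swapping phenyl for furan-3-yl on a shared core

The compounds below may be only part of what the source reports. "The series", "measured", "known", "first", "only" and "open" are said of these compounds alone.

Compound 1 `Cc1nc(N)c2c(-c3ccccc3)cn([C@@H]3O[C@H](CO)[C@@H](O)[C@H]3O)c2n1` was tested in an ADME assay on MRC5 cells (Homo sapiens), read by MTT assay, with a stated time of 72 h; on this read-out higher numbers stand for weaker inhibition and lower numbers for stronger inhibition. In this assay compound 1 gives > 100000 nM, which is a limit of the assay rather than a number. Compound 2 `Nc1nc(N)c2c(-c3ccccc3)cn([C@@H]3O[C@H](CO)[C@@H](O)[C@H]3O)c2n1` differs from compound 1 by an amino in place of methyl on an aromatic carbon, and in this assay compound 2 gives > 100000 nM, again a limit. The step that the two limits leave unreadable from compound 1 to compound 2 therefore cannot be read. Compound 3 `CNc1ncnc2c1c(-c1cccs1)cn2[C@@H]1O[C@H](CO)[C@@H](O)[C@H]1O` carries a different pattern on the shared core, and in this assay compound 3 gives > 100000 nM, also a limit. All three measured values sit at one place, as shown by the limit of > 100000 nM in this assay, at which 3 of the 3 values shown sit; none of them reveals a size for any step.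

Compound 4 `Cc1nc(N)c2c(-c3ccoc3)cn([C@@H]3O[C@H](CO)[C@@H](O)[C@H]3O)c2n1` is not yet measured. It differs from compound 1 as follows: furan-3-yl in place of phenyl on an aromatic carbon. No measured step involves this change, and the one step that is shown is unreadable, so nothing points to a move in either direction beyond the scatter. Compound 4 is therefore expected to stay where the three measured compounds sit, most likely again at the limit. In this assay the value of compound 4 is estimated as 150000 nM within 50000 nM to 500000 nM. The step that the limit leaves unreadable from compound 1 to compound 4 expected from this estimate is small.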

Compound 4, half-maximal inhibitory concentration: > 100000 nM
Compound 4: no number, only a limit; the forecaster's own chance of this, stated with the estimate: 85%; the middle value does not contradict the limit.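

In this assay compound 4 and compound 1 both give only a limit, so the size of the change from phenyl to furan-3-yl cannot be read. All the compounds shown sit at one place: the limit of > 100000 nM in this assay, at which 4 of the 4 values shown sit. They leave open whether any change on the shared core can bring a value within the range of the assay.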